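Lengthening the saturated chain by one carbon

The source may report more compounds than this note shows. Statements on the series, on what has been measured and on what is new or still open speak of the compounds shown alone.

Compound 1, `CCCCCCCC/C=C/CCCCCCCC(=O)Nc1ccccc1C(=O)c1ccccc1`, gives in an assay on microsomes from intestine for inhibition of acyl-CoA:cholesterol acyltransferase (Oryctolagus cuniculus) (a lower number here means a stronger inhibitor, a higher number a weaker inhibitor), only a limit of the assay, > 10000 nM; that is a limit, not a number (the limit of > 10000 nM in this assay, at which 1 of the 3 values shown sits).
Compound 2, `CCCCCCCC/C=C/CCCCCCC(C)(C)C(=O)Nc1c(OC)cc(OC)cc1OC`, gives 44 nM in this assay.
Compound 3, `CCCCCCCC(C)(C)C(=O)Nc1c(OC)cc(OC)cc1OC`, gives 180 nM in this assay.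

Compound 3 holds the higher of the two numbers; its nearest neighbour is compound 2, and the step of a 4.1-fold higher number from compound 2 to compound 3 (0.61 log units; beyond the scatter) is modest yet beyond the scatter. Compound 4, `CCCCCCCCC(C)(C)C(=O)Nc1c(OC)cc(OC)cc1OC`, is not yet measured; it differs from compound 3 by methyl in place of hydrogen on a saturated chain carbon, eight bonds along the chain from a carbonyl carbon. Within the data shown here, only one measured step bears on this change: shortening the chain cost potency, so adding a single carbon back is expected to give compound 4 a small gain in this assay, likely within the scatter, as a 1.4-fold lower number from compound 3 to compound 4 (0.14 log units; within the scatter). Compound 4 is therefore expected at 130 nM, between 55 nM and 320 nM.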

Compound 4, half-maximal inhibitory concentration: 59 nM
Compound 4: middle estimate off by 2.2-fold (0.34 log units), on the high side; low and high end bracket the measured number.
By their numbers in this assay, from the lowest: compounds 2 and 4 (each within the scatter of the next); then compound 3. At a limit, above all of these: compound 1.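

In this assay, among these compounds, methyl in place of hydrogen on this saturated chain carbon, eight bonds along the chain from a carbonyl carbon, counts for more than the earlier compounds showed, with a 3.1-fold lower number from compound 3 to compound 4 (0.48 log units; beyond the scatter). The short saturated chain here already matches the long chain with its double bond, with a 1.3-fold higher number from compound 2 to compound 4 (0.13 log units; within the scatter), so the long chain with its double bond is not needed to reach this level. Nothing shown here explains the gain from this one carbon.

As far as these compounds go, it stays open whether propyl or butyl in this place would hold the number or shift it. From the compounds shown here alone, what a carboxylic acid or an amine at the far end of the chain would give also remains unknown.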